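The compounds below may be only part of what the source reports. "The series", "measured", "known", "first", "only" and "open" are said of these compounds alone.

Compound 3 `Cc1cc(S(=O)(=O)/N=C(\N)N/N=C/C#Cc2ccccc2)c(SCc2ccc(Cl)cc2)cc1Cl` gives 8000 nM in a functional assay on HCT-116 cells (Homo sapiens) for antiproliferative activity, read by MTT assay, with a stated time of 72 h (on this read-out higher numbers stand for weaker inhibition and lower numbers for stronger inhibition), level with compound 1 `Cc1cc(S(=O)(=O)/N=C(\N)N/N=C/C#Cc2ccccc2)c(SCc2ccccc2)cc1Cl`, which gives 8000 nM, the pair together forming the lowest numbers of the three; compound 2 `Cc1cc(S(=O)(=O)/N=C(\N)N/N=C/C#Cc2ccccc2)c(SCc2ccc(C(F)(F)F)cc2)cc1Cl`, with its trifluoromethyl, gives 70000 nM. The step to compound 4 `Cc1cc(S(=O)(=O)/N=C(\N)N/N=C/C#Cc2ccccc2)c(SCc2cccc3ccccc23)cc1Cl` reads (naphthalen-1-yl in place of 4-chlorophenyl on a saturated chain carbon bound to a sulfur). Going by the values given here, no measured step trades a single ring for a fused pair, so only indirect guidance exists: no change at the digits printed from compound 1 to compound 3 (within the scatter), whereas an 8.8-fold higher number from compound 1 to compound 2 (0.94 log units; beyond the scatter). Changes at the benzyl ring have thus ranged from none to a modest weakening, and none has strengthened inhibition. Compound 4 is therefore expected to lie near compound 3 or somewhat weaker, giving an estimated 1.5-fold higher number from compound 3 to compound 4 (0.18 log units; within the scatter). The estimate for compound 4 in this assay is 12000 nM, between 4000 nM and 40000 nM.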

Compound 4, half-maximal inhibitory concentration: 10000 nM
Compound 4: the middle estimate sits 1.2-fold (0.08 log units) above what was measured; measured number inside the range.
By their numbers in this assay, from the lowest: compounds 1, 3 and 4 (each within the scatter of the next); then compound 2.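

In this assay, naphthalen-1-yl on the saturated chain carbon bound to a sulfur, with its 2 six-membered aromatic rings, reads the same as the single-ring 4-chlorophenyl (a 1.3-fold higher number from compound 3 to compound 4 (0.10 log units; within the scatter)) and phenyl (a 1.3-fold higher number from compound 1 to compound 4 (0.10 log units; within the scatter)). Only 4-(trifluoromethyl)phenyl stands apart from it (a 7.0-fold lower number from compound 2 to compound 4 (0.85 log units; beyond the scatter)), so the fused pair is accepted here without the loss seen with trifluoromethyl. No measurement at hand explains this result.

The compounds shown leave open how naphthalen-2-yl, an amine or a carboxylic acid would read at this place. As far as these compounds go, whether any group here can give a lower number than compounds 1, 3 and 4 also remains open.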